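A few compounds are considered here, and "the series" means these few. Any claim that something is new, unique, unknown or untested is made for them only; others in the source may bear on it.

Measured in a functional assay on THP-1 cells (Homo sapiens) for inhibition; on this read-out lower numbers stand for stronger inhibition and higher numbers for weaker inhibition:
Compound 1, `O=C1C[C@H](NC(=O)[C@@H]2CN(C(=O)OCc3ccccc3)C[C@@H]3C/C=C\C[C@H](NC(=O)c4ccccc4)C(=O)N32)C(O)O1`, gives 125 nM.
Compound 2, `O=C1C[C@H](NC(=O)[C@@H]2CN(C(=O)Nc3ccccc3)C[C@@H]3CCCC[C@H](NC(=O)c4ccccc4)C(=O)N32)C(O)O1`, gives 1690 nM.
Compound 3, `O=C1C[C@H](NC(=O)[C@@H]2COC[C@@H]3C/C=C\C[C@H](NC(=O)c4cccc(Cl)c4)C(=O)N32)C(O)O1`, gives 118 nM.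

Among these three numbers compound 3 carries the lowest, yet compound 1 sits within the usual scatter of it, so the two cannot be told apart; only compound 2 lies clearly beyond, on the weaker side. Compound 4, `O=C1C[C@H](NC(=O)[C@@H]2COC[C@@H]3C/C=C\C[C@H](NC(=O)c4ccc5ccccc5c4)C(=O)N32)C(O)O1`, differs from compound 3 in one place: naphthalen-2-yl in place of 3-chlorophenyl on a carbonyl carbon. For the measured compounds named here, no measured pair shows this change, so nothing in the data fixes its size. The step expected for compound 4 in this assay is a 1.3-fold higher number from compound 3 to compound 4 (0.10 log units; within the scatter), no larger than the scatter and in no firm direction. The estimate for compound 4 is therefore 150 nM, within 50 nM to 500 nM.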

Compound 4, half-maximal inhibitory concentration: 62 nM
For compound 4 the middle estimate is 2.4-fold (0.38 log units) above the measured one, and the stated range covers the measured number.
By their numbers in this assay, from the lowest: compounds 4, 3 and 1 (each within the scatter of the next); then compound 2.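

In this assay the swap of 3-chlorophenyl for naphthalen-2-yl on the carbonyl carbon gives a 1.9-fold lower number from compound 3 to compound 4 (0.28 log units; within the scatter) and so stays within the scatter. The earlier compounds shown here held only single-ring aromatic groups here, whereas compound 4 shows that a second aromatic ring is tolerated at this position, with no order between the two groups. Nothing available explains this result. Still open, as far as these compounds go, is whether a cyclohexyl ring, a pyridine ring or a longer alkyl chain on this carbonyl carbon would keep the number in this range.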